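A few compounds are considered here, and "the series" means these few. Any claim that something is new, unique, unknown or untested is made for them only; others in the source may bear on it.

Compound 2 `COc1ccc(C(Nc2ccc([N+](=O)[O-])cc2)n2c(=O)ccc3cc(O)ccc32)cc1` gives 29700 nM in a functional assay on HepG2 cells (Homo sapiens) for inhibition, read by MTT assay; a higher number here means a weaker inhibitor, a lower number a stronger inhibitor. For the measured compounds named here, only one other compound has been measured, compound 1 `COc1ccc(C(Nc2ccccc2)n2c(=O)ccc3cc(O)ccc32)cc1`, which gives 46300 nM in this assay; the two numbers cannot be told apart, since the step from one to the other, a 1.6-fold lower number from compound 1 to compound 2 (0.19 log units; within the scatter), lies within the scatter. Compound 3 `COc1ccc(C(Nc2ccc(Cl)cc2)n2c(=O)ccc3cc(O)ccc32)cc1` has not yet been measured. It differs from compound 2 by chloro in place of nitro on an aromatic carbon. Going by the values given here, the only measured step that bears on this position is the one in which a nitro entered on that same aromatic carbon, and because that step was a 1.6-fold lower number from compound 1 to compound 2 (0.19 log units; within the scatter) and so stayed within the scatter, no shift beyond the scatter is expected from exchanging the nitro for chloro either. The estimated step of a 1.2-fold higher number from compound 2 to compound 3 (0.07 log units; within the scatter) is thus expected to be no change beyond the scatter. Compound 3 is therefore expected to give about 35000 nM in this assay, within a range from 12000 nM to 100000 nM.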

Compound 3, half-maximal inhibitory concentration: 21500 nM
For compound 3 the middle estimate is 1.6-fold (0.21 log units) above the measured one, and the stated range covers the measured number.
By their numbers in this assay, from the lowest: compounds 3, 2 and 1 (each within the scatter of the next, the first and the last beyond it).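

In this assay the exchange of nitro for chloro at this position gives a 1.4-fold lower number from compound 2 to compound 3 (0.14 log units; within the scatter) and so leaves the two groups indistinguishable. Chloro in place of hydrogen gives a 2.2-fold lower number from compound 1 to compound 3 (0.33 log units; beyond the scatter) and is the only step at this position that lies beyond the scatter, though modestly, and compound 3 still cannot be told apart from compound 2. Nothing measured on these compounds beyond this one read-out bears on what lies behind these numbers. The compounds shown leave open whether an amine or a carboxylic acid on this same aromatic carbon would move the number further in either direction. They also leave open whether chloro would give a comparable step on another carbon of this six-membered ring, since only this one place has been varied here.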